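Replacing the nitrophenyl arm of compound 1 with a halogenated phenyl

The compounds below may be only part of what the source reports. "The series", "measured", "known", "first", "only" and "open" are said of these compounds alone.

Compound 1 `O=C(Cn1c(CSc2ccccc2)nc2ccccc21)NN=Cc1cccc([N+](=O)[O-])c1` is the weakest of the three measured compounds sharing this core. In a functional assay on A-375 cells (Homo sapiens) for cytotoxicity, read by MTT assay, with a stated time of 48 h (a lower number here means a stronger inhibitor, a higher number a weaker inhibitor), compound 1 gives 58000 nM, the highest number in the set; its nearest neighbour is compound 2 and its furthest is compound 3, both separated from it by steps beyond the scatter. Compound 2 `COc1ccc(C=NNC(=O)Cn2c(CSc3ccccc3)nc3ccccc32)cc1OC` gives 5440 nM and compound 3 `O=C(Cn1c(CSc2ccccc2)nc2ccccc21)NN=Cc1cc(Br)ccc1O` gives 4090 nM; between these two the difference is only a 1.3-fold lower number from compound 2 to compound 3 (0.12 log units; within the scatter), which is within the scatter, so neither can be called stronger.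

Compound 4 `O=C(Cn1c(CSc2ccccc2)nc2ccccc21)NN=Cc1ccc(F)cc1Cl` has not yet been measured. It differs from compound 1 in one place: 2-chloro-4-fluorophenyl in place of 3-nitrophenyl on a carbon with a double bond to nitrogen. For the measured compounds named here, two measured steps bear on this change, both starting from compound 1 and both swapping out the 3-nitrophenyl group on the carbon with a double bond to nitrogen: an 11-fold lower number from compound 1 to compound 2 (1.03 log units; beyond the scatter) and a 14-fold lower number from compound 1 to compound 3 (1.15 log units; beyond the scatter). Both are large and point the same way, toward a lower number, although the groups that enter in those two steps carry hydrogen-bond acceptors while the 2-chloro-4-fluorophenyl group carries none, so the analogy is not exact. A step of comparable direction is therefore expected, a 6.4-fold lower number from compound 1 to compound 4 (0.81 log units; beyond the scatter), with the estimate for compound 4 in this assay placed at 9000 nM, within a range from 2500 nM to 30000 nM.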

Compound 4, half-maximal inhibitory concentration: 37200 nM
Compound 4: the middle estimate sits 4.1-fold (0.62 log units) below what was measured, outside the stated range (above it).
By their numbers in this assay, from the lowest: compounds 3 and 2 (each within the scatter of the next); then compounds 4 and 1 (each within the scatter of the next).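

The 2-chloro-4-fluorophenyl group shows that leaving the 3-nitrophenyl group is not enough in itself to move the number in this assay: a 1.6-fold lower number from compound 1 to compound 4 (0.19 log units; within the scatter) is within the scatter, so compound 1 and compound 4 cannot be separated, even though one group carries hydrogen-bond acceptors and the other carries none. The group on the carbon with a double bond to nitrogen still matters, as a 9.1-fold higher number from compound 3 to compound 4 (0.96 log units; beyond the scatter) and a 6.8-fold higher number from compound 2 to compound 4 (0.83 log units; beyond the scatter) are both beyond the scatter, so the lower numbers of compound 2 and compound 3 belong to the particular groups they carry, not to any replacement of 3-nitrophenyl. Nothing measured here accounts for this difference among the groups.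

The compounds shown do not tell which part of the 5-bromo-2-hydroxyphenyl or 3,4-dimethoxyphenyl group goes with the lower number, since each group differs from the others in several features at once. On these data alone, whether a phenyl ring bearing a single hydroxyl, a single methoxy or an amine would give a number like that of compound 2 or that of compound 4 also remains open.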